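A few compounds are considered here, and "the series" means these few. Any claim that something is new, unique, unknown or untested is made for them only; others in the source may bear on it.

Compound 1 `C=C[C@@](C)(/C=C/c1ccc(Nc2ccc(OC)c(F)c2)cc1)CCC=C(C)C`: > 26000 nM (a limit)
Compound 2 `C=C[C@@](C)(/C=C/c1ccc(Nc2c(F)cc(F)cc2F)cc1)CCC=C(C)C`: > 26000 nM (a limit)
Compound 3 `C=C[C@@](C)(/C=C/c1ccc(Nc2ccc(Cl)c(Cl)c2)cc1)CCC=C(C)C`: not yet measured

In a functional assay on Raji cells (Homo sapiens) for cytotoxicity, with a stated time of 72 h (a higher number here means that more compound is needed for the effect, a lower number that less compound is needed), compound 2 gives > 26000 nM, which is a limit of the assay and not a number. Within the data shown here, the series so far stands at the limit of > 26000 nM in this assay, at which 2 of the 2 values shown sit.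

The next change is 3,4-dichlorophenyl in place of 2,4,6-trifluorophenyl on a nitrogen on an aromatic ring. Among the measured compounds shown here, only one measured step bears on it, a step that the two limits leave unreadable from compound 1 to compound 2, and it offers no size to carry over. The expectation therefore rests on the two compounds sharing (the limit of > 26000 nM in this assay, at which 2 of the 2 values shown sit), and it favours little change, with a slight lean toward a lower number. The expected step is an at least 1.1-fold lower number from compound 2 to compound 3 (0.07 log units; that floor lies within the scatter). For compound 3 the estimated value in this assay is 22000 nM, with an expected range of 9000 nM to 30000 nM, and a further limit result would be no surprise.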

Compound 3, half-maximal effective concentration: > 26000 nM
Compound 3: only a limit was reported; the forecaster's own chance of this, stated with the estimate: 60%; middle value at least 1.1-fold (0.07 log units) away from the limit.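

In this assay compound 3 gives > 26000 nM, a limit and not a number. Among these compounds, no step among compound 1, compound 2 and compound 3 can be read. The compounds shown leave open whether any group on this nitrogen gives a readable value, as the series stands at: the limit of > 26000 nM in this assay, at which 3 of the 3 values shown sit.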